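Methoxy for Fluoro on the Aryl Piperazine

A few compounds are considered here, and "the series" means these few. Any claim that something is new, unique, unknown or untested is made for them only; others in the source may bear on it.

In a functional assay on the whole organism (strain CD-1) with Mus musculus as the target, in the maximal electroshock model, with a stated time of 2 h (a higher number here means that more compound is needed for the effect, a lower number that less compound is needed), three compounds of one shared core have been examined. Compound 1 `CC1(c2ccccc2)CC(=O)N(CC(=O)N2CCN(c3ccccc3Cl)CC2)C1=O` gives "not active" (no number reported), with no number reported. Among the measured compounds shown here, compound 2 `CC1(c2ccccc2)CC(=O)N(CC(=O)N2CCN(c3cccc(C(F)(F)F)c3)CC2)C1=O` gives 300 mg/kg, the only number so far. Compound 3 `CC1(c2ccccc2)CC(=O)N(CC(=O)N2CCN(c3ccccc3F)CC2)C1=O` gives "not active" (no number reported), again with no number reported. Compound 3 therefore stands beside compound 1 as one of two compounds for which the assay returned no figure, while compound 2 alone carries a measured dose.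

The next compound, compound 4 `COc1ccccc1N1CCN(C(=O)CN2C(=O)CC(C)(c3ccccc3)C2=O)CC1`, differs from compound 3 in a single spot: methoxy in place of fluoro on an aromatic carbon. Read one bond further out, the change is 2-fluorophenyl to 2-methoxyphenyl.

For the measured compounds named here, no step between two measured compounds exists for this change, so its size cannot be read from the data. The two compounds without a number, compound 1 and compound 3, both carry a group ortho to a large group, and compound 4 keeps a group in that place. The expectation is that compound 4 again gives no number, or at best a dose near that of compound 2. If a number is reported, compound 4 is expected to lie near 300 mg/kg, in a range from 100 mg/kg to 600 mg/kg.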

Compound 4, minimum effective dose: 300 mg/kg
Estimate against measurement, compound 4: no gap at the digits printed, within the range that was stated.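

In this assay compound 4 gives 300 mg/kg, so a group in the place ortho to a large group does not by itself rule out a reported dose, even though compound 1 with chloro and compound 3 with fluoro return no number there. Among the compounds shown here, the one step that can be read shows no change at the digits printed from compound 2 to compound 4 (within the scatter), so 2-methoxyphenyl and 3-(trifluoromethyl)phenyl cannot be told apart in this test. For the compounds shown here, compound 1 and compound 3 carry no number, so no step touching them can be read, and the size of the change from fluoro to methoxy stays unknown.

Still open, from the compounds shown here alone, is whether ethoxy, a hydroxyl group or an amine in that same place would give a reported dose, and how such a dose would compare with that of compound 4. Nothing measured here accounts for methoxy giving a number where fluoro gives none.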